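From naphthalen-1-yl to 2-chlorophenyl: an expected step

The source may hold more compounds than are shown below. What is called first, only, known or untested is meant among the compounds shown, and "the series" means these compounds.

Measured in a functional assay on MCF7 cells (Homo sapiens) for cytotoxicity, read by MTT assay, with a stated time of 24 h; on this read-out higher numbers stand for weaker inhibition and lower numbers for stronger inhibition:
Compound 1 `CCNc1cc(-c2ccc(NC(=O)Nc3ccc(C(F)(F)F)cc3)cc2C)ccn1`: 6870 nM
Compound 2 `CCNc1cc(-c2ccc(NC(=O)Nc3cccc4ccccc34)cc2C)ccn1`: 15500 nM

Of these two compounds, compound 2 has the higher number (15500 nM). Compound 3 `CCNc1cc(-c2ccc(NC(=O)Nc3ccccc3Cl)cc2C)ccn1` carries 2-chlorophenyl in place of naphthalen-1-yl on an amide-type nitrogen. Within the data shown here, one measured step bears on this change, made at the same place: a 2.3-fold higher number from compound 1 to compound 2 (0.35 log units; beyond the scatter). That step was modest, and naphthalen-1-yl gave the higher number. A modest move to a lower number is therefore expected, an estimated 1.7-fold lower number from compound 2 to compound 3 (0.24 log units; within the scatter). Compound 3 is expected at 9000 nM (estimated range 4000 nM to 20000 nM).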

Compound 3, half-maximal inhibitory concentration: 8350 nM
The estimate for compound 3 lay 1.1-fold (0.03 log units) above the measured number; low and high end bracket the measured number.
By their numbers in this assay, from the lowest: compounds 1, 3 and 2 (each within the scatter of the next, the first and the last beyond it).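

In this assay, 2-chlorophenyl in place of naphthalen-1-yl on the amide-type nitrogen gives a 1.9-fold lower number from compound 2 to compound 3 (0.27 log units; within the scatter) and 2-chlorophenyl in place of 4-(trifluoromethyl)phenyl gives a 1.2-fold higher number from compound 1 to compound 3 (0.08 log units; within the scatter) at the same place. The 2-chlorophenyl compound therefore cannot be told apart from either of the others, although those two differ beyond the scatter. No measurement shown here accounts for these numbers.

On these data alone, it remains open whether an unsubstituted phenyl would read differently from 2-chlorophenyl. As far as these compounds go, it also remains open how a group without an aromatic ring, such as a longer alkyl chain or one ending in an amine or a carboxylic acid, would fare on this nitrogen.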